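The source may hold more compounds than are shown below. What is called first, only, known or untested is meant among the compounds shown, and "the series" means these compounds.

Compounds measured so far:
- compound 1 `CC(C)N(Cc1cccc(OCCCCCC(=O)O)c1)C(=O)c1ccc(-c2cccc3ccccc23)cc1`: > 26000 nM
- compound 2 `COc1cccc(-c2ccc(C(=O)N(Cc3cccc(OCCCCCC(=O)O)c3)C(C)C)cc2)c1`: > 26000 nM
- compound 3 `CCOC(=O)CCCCCOc1cccc(CN(C(=O)c2ccc(-c3cccc4ccccc34)cc2)C(C)C)c1`: > 26000 nM

In an ADME assay on HepG2 cells (Homo sapiens) for cytotoxicity, read by CellTiter-Glo and resazurin assay, with a stated time of 72 h (a lower number here means that less compound is needed, a higher number that more compound is needed for the effect), compound 3 gives > 26000 nM, which is a limit of the assay and not a number. Compound 1 likewise gives only a limit in this assay, > 26000 nM. Compound 2 also reaches only a limit, > 26000 nM. All three readings therefore sit at the same point, (the limit of > 26000 nM in this assay, at which 3 of the 3 values shown sit), and none of them yields a measured step.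

The change from compound 3 to compound 4 `CCOC(=O)CCCCCOc1cccc(CN(C(=O)c2ccc(-c3cccc(OC(C)C)c3)cc2)C(C)C)c1` is 3-isopropoxyphenyl in place of naphthalen-1-yl on an aromatic carbon. Within the data shown here, two measured steps touch on it. The step that the two limits leave unreadable from compound 1 to compound 2 exchanges the same aryl group on the same carbon for a related alkoxyphenyl and is unreadable between two limits. The step that the two limits leave unreadable from compound 1 to compound 3 concerns the ester end of the chain that compound 4 shares with compound 3 and is equally unreadable. Neither step gives a direction or a size, so no movement beyond the scatter is expected for this assay, and the reading for compound 4 is expected to end at the same limit.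

For compound 4 the expected value is 40000 nM, with a range from 15000 nM to 120000 nM. This means an expected step that the limit leaves unreadable from compound 3 to compound 4 for compound 4.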

Compound 4, half-maximal effective concentration: > 26000 nM
Compound 4: only a limit was reported; the forecaster's own chance of this, stated with the estimate: 85%; the middle value is on the limit's open side.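

In this assay compound 4 gives > 26000 nM, which is a limit of the assay and not a number, so the step from compound 3 cannot be read. All the readings stand at one point: the limit of > 26000 nM in this assay, at which 4 of the 4 values shown sit.

The compounds shown leave open how large any of these concentrations is, and whether exchanging the aryl group or the ester end changes it.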